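A Benzyl(methyl)amino Analogue Where Both Measured Values Are Limits

The compounds below may be only part of what the source reports. "The series", "measured", "known", "first", "only" and "open" are said of these compounds alone.

Compound 1 `Cc1cc(NCCO)nc(SCc2nc3ccccc3[nH]2)n1`: in a functional assay on MGC-803 cells (Homo sapiens) for cytotoxicity, read by MTT assay, with a stated time of 72 h (on this read-out higher numbers stand for weaker inhibition and lower numbers for stronger inhibition), compound 1 gives > 100000 nM, a limit of the assay rather than a number.
Compound 2 `Cc1cc(N2CCNCC2)nc(SCc2nc3ccccc3[nH]2)n1`: in this assay compound 2 gives > 100000 nM, again a limit of the assay.

Compound 2 stands at the ceiling of what this assay reports, and compound 1 sits at the same ceiling (the limit of > 100000 nM in this assay, at which 2 of the 2 values shown sit). Going by the values given here, the only measured step, a step that the two limits leave unreadable from compound 1 to compound 2, has no readable size, since both of its ends are limits.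

Compound 3 `Cc1cc(N(C)Cc2ccccc2)nc(SCc2nc3ccccc3[nH]2)n1` differs from compound 2 by benzyl(methyl)amino in place of piperazin-1-yl on an aromatic carbon. Among the compounds with values here, no measured step bears on this change, and the series so far holds nothing but limits, which leaves no scale for an expectation. Compound 3 is expected to stay weak in this assay, with an expected step of a number no higher from compound 2 to compound 3 (the limit leaves the size open). The estimate for compound 3 is 100000 nM, within a range from 20000 nM to 300000 nM, with a real chance that only a limit is reported.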

Compound 3, half-maximal inhibitory concentration: 31300 nM
For compound 3 the middle estimate is 3.2-fold (0.50 log units) above the measured one; the measured number falls inside the stated range.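

Compound 3 gives the series its first real number in this assay, which shows that changing the group at this position of the shared core can register in the read-out. Benzyl(methyl)amino in place of piperazin-1-yl gives an at least 3.1-fold lower number from compound 2 to compound 3 (0.50 log units; beyond the scatter), and benzyl(methyl)amino in place of (2-hydroxyethyl)amino gives an at least 3.1-fold lower number from compound 1 to compound 3 (0.50 log units; beyond the scatter). Both steps start from a limit of the assay, so each gives only a minimum size, and the step between the two earlier compounds cannot be read: the limit of > 100000 nM in this assay, at which 2 of the 3 values shown sit.

The entering group differs from piperazin-1-yl in several ways at once, including its carbon-only aromatic ring and its 0 hydrogen-bond donors, so the compounds shown cannot say which difference matters. They also leave open whether a benzylamino group without the methyl, or a phenethylamino group with its longer chain, would give a lower number still.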